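Para-substituent variation on a shared imidazole-linked series

This account rests on a few compounds, and the source may have more. Where it says the series, first, only, none or still open, it means among the compounds named here.

Measured compounds:
compound 1 `CCC(C)(C)Cc1c[nH]c(CCc2ccc(-n3ccnn3)cc2)n1`: 93 nM
compound 2 `CCC(C)(C)Cc1c[nH]c(CCc2ccc(-c3ccc(F)cn3)cc2)n1`: 97 nM
compound 3 `CCC(C)(C)Cc1c[nH]c(CCc2ccc(-c3cccnc3C(=O)O)cc2)n1`: 95 nM

All three were read in a functional assay on HEK293 cells for agonist activity at Bombesin receptor subtype-3 (Homo sapiens), read by luminescence and calcium flux, with a stated time of 10 min; on this read-out lower numbers stand for an effect already at smaller amounts and higher numbers for an effect only at larger amounts of compound. Compound 3 stands among three values that lie within the scatter of one another: a 1.0-fold higher number from compound 1 to compound 3 (0.01 log units; within the scatter) and a 1.0-fold lower number from compound 2 to compound 3 (0.01 log units; within the scatter), and likewise a 1.0-fold higher number from compound 1 to compound 2 (0.02 log units; within the scatter). No exchange at this aromatic carbon has so far moved the number beyond the scatter.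

Compound 4 `CCC(C)(C)Cc1c[nH]c(CCc2ccc(-n3cncn3)cc2)n1` alters the same group on the aromatic carbon of the six-membered ring of carbon only, para to a large group: 1H-1,2,4-triazol-1-yl in place of 2-carboxypyridin-3-yl on an aromatic carbon. For the measured compounds named here, the steps that bear on it are the two into compound 3 and the one between compounds 1 and 2, each within the scatter. Compound 1 carries 1H-1,2,3-triazol-1-yl at that place and gives 93 nM. On that basis the expected step for compound 4 is no change at the digits printed from compound 3 to compound 4 (within the scatter), nothing beyond the scatter. The estimate for compound 4 is 95 nM, with a range from 50 nM to 190 nM.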

Compound 4, half-maximal effective concentration: 89 nM
Beside the measured number, compound 4's estimate is 1.1-fold (0.03 log units) above it, and the stated range covers the measured number.
By their numbers in this assay, from the lowest: compounds 4, 1, 3 and 2 (each within the scatter of the next).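

Moving a ring nitrogen within the triazole, the one change here that keeps the five-membered ring attached through nitrogen, leaves the number within the scatter (a 1.0-fold lower number from compound 1 to compound 4 (0.02 log units; within the scatter)), so at this aromatic carbon this assay does not separate the 1H-1,2,3-triazol-1-yl and 1H-1,2,4-triazol-1-yl isomers. The step that removes the larger 2-carboxypyridin-3-yl, with its hydrogen-bond donor, and the step that removes 5-fluoropyridin-2-yl also stay within the scatter (a 1.1-fold lower number from compound 3 to compound 4 (0.03 log units; within the scatter); a 1.1-fold lower number from compound 2 to compound 4 (0.04 log units; within the scatter)), so the four groups shown form one flat set of values. Nothing available explains this flatness.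

Open, from the compounds shown here alone, is whether any group at this place moves the number beyond the scatter, for example a plain hydrogen, an amine or a longer alkyl chain. Going by these compounds, all four compounds share the same core, so how far this flatness holds with another group elsewhere on it also remains open.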